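The source may hold more compounds than are shown below. What is called first, only, known or untested is meant among the compounds shown, and "the series" means these compounds.

Compound 1 `COC(=O)C1=C(C)N=C(C)/C(=C(\O)OC)C1c1ccccc1Cl` gives 2.19 nM in a functional assay (muscle tissue) with Cavia porcellus as the target; a higher number here means that more compound is needed for the effect, a lower number that less compound is needed. Compound 2 `C=Cc1ccccc1C1C(C(=O)OC)=C(C)N=C(C)/C1=C(\O)OC` gives 4.47 nM, and compound 3 `COC(=O)C1=C(C)N=C(C)/C(=C(\O)OC)C1c1cc(Cl)cc(Cl)c1` gives 93.3 nM. Compound 2 thus holds the second highest number of the three: a 2.0-fold higher number from compound 1 to compound 2 (0.31 log units; beyond the scatter) lies nearest to it, while a 21-fold higher number from compound 2 to compound 3 (1.32 log units; beyond the scatter) lies furthest. Compound 4 `COC(=O)C1=C(C)N=C(C)/C(=C(\O)OC)C1c1cccc(O)c1` carries 3-hydroxyphenyl in place of 2-vinylphenyl on a saturated ring carbon. Going by the values given here, the steps that bear on this change are the two exchanges of the aryl group on the saturated ring carbon, a 21-fold higher number from compound 2 to compound 3 (1.32 log units; beyond the scatter) and a 43-fold higher number from compound 1 to compound 3 (1.63 log units; beyond the scatter), both large rises. Because a 21-fold higher number from compound 2 to compound 3 (1.32 log units; beyond the scatter) came with 3,5-dichlorophenyl while compound 4 carries 3-hydroxyphenyl, a smaller rise, still beyond the scatter, is expected. Compound 4 is therefore estimated at 30 nM, between 8 nM and 150 nM. This expectation means a 6.7-fold higher number from compound 2 to compound 4 (0.83 log units; beyond the scatter).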

Compound 4, half-maximal effective concentration: 1000 nM
For compound 4 the middle estimate is 33-fold (1.52 log units) below the measured one; the whole stated range lies below it.
By their numbers in this assay, from the lowest: compound 1; then compound 2; then compound 3; then compound 4.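

In this assay, 3-hydroxyphenyl on this saturated ring carbon needs more compound than any other aryl group of the four, with a 220-fold higher number from compound 2 to compound 4 (2.35 log units; beyond the scatter) and a 460-fold higher number from compound 1 to compound 4 (2.66 log units; beyond the scatter). The step also extends past 3,5-dichlorophenyl, which had held the highest number, with an 11-fold higher number from compound 3 to compound 4 (1.03 log units; beyond the scatter). Nothing available here explains this rise. Still open, from the compounds shown here alone, is whether the result belongs to the hydroxy group itself or to its place on the phenyl ring. A 3-methoxyphenyl, 3-aminophenyl or 2-hydroxyphenyl group on the same carbon would bear on that.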